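This account rests on a few compounds, and the source may have more. Where it says the series, first, only, none or still open, it means among the compounds named here.

Compound 1, `COc1cc2c(cc1O)O[C@H](c1ccccc1)[C@@H](O)C2=O`: > 100000 nM
Compound 2, `COc1c(O)cc2c(c1O)C(=O)[C@H](O)[C@@H](c1ccccc1)O2`: > 100000 nM
Compound 3, `COc1ccc(-c2coc3cc(O)ccc3c2=O)c(O)c1`: 69800 nM

Of the compounds shown here, three have been tested in a functional assay on HeLa cells (Homo sapiens) for cytotoxicity, read by MTT assay, with a stated time of 72 h; a lower number here means a stronger inhibitor, a higher number a weaker inhibitor. Compound 1 gives > 100000 nM, which is a limit of the assay and not a number. Compound 2 likewise gives > 100000 nM, again a limit. Among the measured compounds shown here, compound 3 gives 69800 nM, the only number among the three.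

Compound 2 differs from compound 1 by hydroxy in place of hydrogen on an aromatic carbon, and the resulting step, a step that the two limits leave unreadable from compound 1 to compound 2, cannot be read because both values sit at the limit of > 100000 nM in this assay, at which 2 of the 3 values shown sit. The difference between the core of compound 3 and that of compound 1 is not broken down here.

Compound 4, `COc1ccc(-c2coc3cc(O)cc(O)c3c2=O)c(O)c1`, is not yet measured. It differs from compound 3 by hydroxy in place of hydrogen on an aromatic carbon. This is the same kind of change as that from compound 1 to compound 2, but not the same: in compound 2 the hydroxy is also ortho to a methoxy group, whereas in compound 4 it is not.

Since the measured step is unreadable, the expectation rests only on compound 3 and its value 69800 nM; compound 4 is expected to move by a 1.4-fold lower number from compound 3 to compound 4 (0.14 log units; within the scatter). Compound 4 is therefore estimated at 50000 nM, between 20000 nM and 150000 nM.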

Compound 4, half-maximal inhibitory concentration: > 100000 nM
Compound 4 ended at the assay's limit (the forecaster's own chance of this, stated with the estimate: 30%); middle value at least 2.0-fold (0.30 log units) from the limit.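

In this assay, compound 4 gives > 100000 nM, which is a limit of the assay and not a number. Hydroxy in place of hydrogen on an aromatic carbon of the core of compound 3 gives an at least 1.4-fold higher number from compound 3 to compound 4 (0.15 log units; that floor lies within the scatter), so this core shows no drop in the number, yet the true size of the step remains unknown. The same kind of change on the core of compound 1 cannot be read, so no two measured sizes can be set side by side, and the data neither support nor refute carrying the change from one core to the other, because most of the series sits at one bound: the limit of > 100000 nM in this assay, at which 3 of the 4 values shown sit.

The compounds shown leave open whether any other group on these cores would bring a reading clear of that limit. As far as these compounds go, an amine or a carboxylic acid in place of the added hydroxy, or a longer chain in place of the methoxy, remains untested among them in this assay.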